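This account rests on a few compounds, and the source may have more. Where it says the series, first, only, none or still open, it means among the compounds named here.

Going by the values given here, compound 3, `CC1=C(C(=O)OCC2CCC2)C(c2cccs2)NC(=O)N1`, is one of three compounds measured in an assay on membranes from CHO cells for displacement of a labelled ligand from adenosine receptor A1 (Homo sapiens), read by scintillation counting, with a stated time of 60 min, tested at 1 uM; on this read-out lower numbers stand for less inhibition and higher numbers for more inhibition at the one concentration tested (going by the name of the read-out). In this assay compound 3 gives 39%, the second highest of the three numbers. Compound 1, `CC1=C(C(=O)OC(C)(C)C)C(c2ccsc2)NC(=O)N1`, gives 15%, and compound 2, `CC1=C(C(=O)OCc2ccccc2)C(c2ccsc2)NC(=O)N1`, gives 57%. Among the compounds with values here, the one step that links two measured compounds in one place, a number 42 percentage points higher from compound 1 to compound 2 (beyond the scatter), concerns the ester alcohol part, so it does not bear on the change to compound 4.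

Compound 4, `CC1=C(C(=O)OCC2CCC2)C(c2ccsc2)NC(=O)N1`, differs from compound 3 as follows: thiophen-3-yl in place of thiophen-2-yl on a saturated ring carbon. Compounds 1 and 2 carry this thiophen-3-yl too, but each also has another ester, so their values show nothing directly about the swap itself. Within the data shown here, the data hold no measured pair that isolates this change. Compound 4 is therefore expected to show a step of a number 1 percentage points higher from compound 3 to compound 4 (within the scatter), that is none beyond the scatter. Compound 4 is estimated at 40%, within a range from 22% to 58%.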

Compound 4, a percentage reported as inhibition, at one concentration (the size of the read-out at that concentration, not a potency): 48%
The estimate for compound 4 lay 8 percentage points below the measured number; the measured number falls inside the stated range.
By their numbers in this assay, from the lowest: compound 1; then compounds 3, 4 and 2 (each within the scatter of the next, the first and the last beyond it).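

In this assay, thiophen-3-yl in place of thiophen-2-yl on the saturated ring carbon now stands as an isolated change, and it gives a number 9 percentage points higher from compound 3 to compound 4 (within the scatter), so this pair shows no effect of the swap that can be told from the scatter. With thiophen-3-yl held fixed, the ester part can matter: cyclobutylmethyl in place of tert-butyl gives a number 33 percentage points higher from compound 1 to compound 4 (beyond the scatter). By contrast, cyclobutyl in place of phenyl on the saturated chain carbon gives a number 9 percentage points lower from compound 2 to compound 4 (within the scatter), which shows no separation between these two esters.

Going by these compounds, whether a furan ring or a pyridine ring on this saturated ring carbon would read differently stays open, as does whether the thiophene swap would give the same result with the benzyl or tert-butyl ester. Nothing available here accounts for any of these steps.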